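The source may hold more compounds than are shown below. What is called first, only, known or untested is meant among the compounds shown, and "the series" means these compounds.

Working notes on the series. The shared core of compound 1 `O=C1O/C(=C\Cn2cnc3c(F)nc(F)c(Cl)c32)C(OCc2ccccc2)=C1OCc1ccccc1` carries two benzyloxy groups on an unsaturated lactone, and the chain on the exocyclic double bond ends in a fused bicyclic base. In a functional assay on L1210/0 cells (Mus musculus) for antiproliferative activity, read by MTT assay, with a stated time of 72 h (a higher number here means a weaker inhibitor, a lower number a stronger inhibitor), compound 1 has no single number: it stands as "not determined" (no result reported), so its place among the measured members cannot be fixed. The measured members are the ring-opened hydroxy-lactam types. Compound 2 `O=C1NC(O)(CCn2cnc3ccn(CCC4(O)NC(=O)C(OCc5ccccc5)=C4OCc4ccccc4)c3c2=O)C(OCc2ccccc2)=C1OCc1ccccc1` gives 4400 nM; 7600 nM (2 entries) in this assay, and the several entries of compound 2 (the several entries of compound 2 in this assay, 4400 nM; 7600 nM (2 entries)) lie within the usual scatter of each other. Compound 3 `COc1nc(OC)c2c(ccn2CCC2(O)NC(=O)C(OCc3ccccc3)=C2OCc2ccccc2)n1` gives 107000 nM in this assay, a weaker result than compound 2 by a margin well beyond the scatter.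

Compound 4 `O=C1O/C(=C\Cn2cnc3ncc(Br)c-3c2)C(OCc2ccccc2)=C1OCc1ccccc1` is the next member to be measured. Relative to compound 1 the change is a group of 10 heavy atoms (6 carbon, 3 nitrogen, 1 bromine; one five-membered aromatic ring with 1 hetero atom, one six-membered aromatic ring with 2 hetero atoms) in place of a group of 12 heavy atoms (6 carbon, 3 nitrogen, 2 fluorine, 1 chlorine; one five-membered aromatic ring with 2 hetero atoms, one six-membered aromatic ring with 1 hetero atom), on a saturated chain carbon bound to a double-bonded chain carbon. Among the compounds with values here, no measured step in this assay covers such a change, and compound 1 itself offers no number from which a direction could be read; the expectation for compound 4 therefore rests only on the range spanned by compound 2 and compound 3.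

Compound 4 is expected to give about 20000 nM in this assay, with a range from 3000 nM to 150000 nM.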

Compound 4, half-maximal inhibitory concentration: 15000 nM
Compound 4: middle estimate off by 1.3-fold (0.12 log units), on the high side, within the range that was stated.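

No new step can be read: compound 1 has no number in this assay, while compound 4 gives 15000 nM. The compounds shown leave open how the swap of the fused bicyclic base on the saturated chain carbon bears on antiproliferative activity.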